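A chloropyridinyl phosphate ester and its stability expectation

This account rests on a few compounds, and the source may have more. Where it says the series, first, only, none or still open, it means among the compounds named here.

The study compares aryl phosphate esters of nucleosides in a physicochemical assay for metabolic stability, read by HPLC; a higher number here means that the compound lasts longer, a lower number that the compound disappears faster. Compound 1 `O=c1ccn([C@H]2CC[C@@H](COP(=O)(O)Oc3cccnc3)O2)c(=O)[nH]1` gives 50.2 h in this assay. Compound 2 `Cc1ccc(OP(=O)(O)OC[C@H]2O[C@@H](n3cc(C)c(=O)[nH]c3=O)C[C@@H]2N=[N+]=[N-])cn1` gives 28.9 h in this assay, a number that sits within the usual scatter of the number for compound 1, so the two cannot be told apart on these data. For the measured compounds named here, no step between two measured compounds that differ in one place is available, so there is no measured precedent for the change now considered. Compound 3 `Cc1cn([C@H]2C[C@H](N=[N+]=[N-])[C@@H](COP(=O)(O)Oc3cccnc3Cl)O2)c(=O)[nH]c1=O` differs from compound 2 in a single place: 2-chloropyridin-3-yl in place of 6-methylpyridin-3-yl on an oxygen. With nothing in the data to anchor the size of such a change, the step from compound 2 to compound 3 is expected to be a 1.2-fold lower number from compound 2 to compound 3 (0.06 log units; within the scatter), that is, no change beyond the scatter, with a slight lean downward. Compound 3 is therefore estimated at 25 h in this assay, within a range from 12 h to 50 h.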

Compound 3, half-life: 16.3 h
The estimate for compound 3 lay 1.5-fold (0.19 log units) above the measured number; measured number inside the range.
By their numbers in this assay, from the lowest: compounds 3, 2 and 1 (each within the scatter of the next, the first and the last beyond it).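

In this assay, for the compounds shown here, the exchange of 6-methylpyridin-3-yl for 2-chloropyridin-3-yl, on an oxygen whose other neighbours are phosphorus, gives the first step that can be read at this place: a 1.8-fold lower number from compound 2 to compound 3 (0.25 log units; within the scatter). On this single pair, then, the two groups cannot be told apart at this position, although they carry different substituents and the rest of the structure stays the same. Nothing measured here bears on why the two numbers stand as they do.

The compounds shown leave open whether the same holds for a different group on that oxygen, such as a plain phenyl, a pyridinyl ring bearing an amine or a carboxylic acid, or a longer alkyl chain. They also leave open whether this exchange would give a similar step on the core of compound 1, which differs from compound 2 in more than one place.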